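Permeability across the benzothiazole-amine series: compound 4

A few compounds are considered here, and "the series" means these few. Any claim that something is new, unique, unknown or untested is made for them only; others in the source may bear on it.

Compound 1 `CNC(=O)c1cc(Oc2ccc3sc(Nc4cccc(C(C)(C)C)c4)nc3c2)ccn1` stands level with the two benzoxazole analogues on the numbers available. In an ADME assay on Caco-2 cells (Homo sapiens) for permeability, in the apical to basolateral direction (on this read-out lower numbers stand for lower permeability and higher numbers for higher permeability), compound 1 gives 10 10^-6 cm/s. Compound 2 `CCc1ccccc1Nc1nc2cc(Oc3ccnc(C(=O)NC)c3)ccc2o1` gives 10 10^-6 cm/s in this assay, and compound 3 `CCc1ccc(Nc2nc3cc(Oc4ccnc(C(=O)NC)c4)ccc3o2)cc1` gives 10 10^-6 cm/s. Among the compounds with values here, the only single-point step among the measured compounds, no change at the digits printed from compound 2 to compound 3 (within the scatter), is a swap of one substituted phenyl for another on the same nitrogen and stays within the scatter. Compound 1 matches both of them within the scatter, so no order among compounds 1, 2 and 3 can be read from these values.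

Compound 4 `CNC(=O)c1cc(Oc2ccc3sc(Nc4ccc(Cl)cc4)nc3c2)ccn1` differs from compound 1 by 4-chlorophenyl in place of 3-(tert-butyl)phenyl on a nitrogen on an aromatic ring. This again replaces the aryl group on the nitrogen on an aromatic ring; the measured step from compound 2 to compound 3 is of the same kind, though it exchanges ethylphenyl isomers rather than a tert-butyl for a chlorine, and it was flat. Within the data shown here, no measured step involves a tert-butyl or a chlorine. On this basis the expectation for compound 4 in this assay is a step of no size beyond the scatter, no change at the digits printed from compound 1 to compound 4 (within the scatter), relative to compound 1. Compound 4 is estimated at 10 10^-6 cm/s, with a range from 5 10^-6 cm/s to 20 10^-6 cm/s.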

Compound 4, apparent permeability: 10 10^-6 cm/s
The estimate for compound 4 equals the measured number at the digits printed; measured number inside the range.
By their numbers in this assay, from the lowest: compounds 1, 2, 3 and 4 (each within the scatter of the next).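

In this assay the exchange of 3-(tert-butyl)phenyl for 4-chlorophenyl on a nitrogen on an aromatic ring gives no change at the digits printed from compound 1 to compound 4 (within the scatter) on the core of compound 1. The earlier step only moved an ethyl group between two ethylphenyl isomers on a different core, whereas this one replaces a carbon-only substituted phenyl of 10 heavy atoms with a chlorine-bearing one of 7 heavy atoms, and it still stays within the scatter. The two steps at this nitrogen are therefore both flat on the two cores shown, with no compound going against that reading, although the pattern holds only for these four compounds. No measurement on hand accounts for this flat result.

From the compounds shown here alone, all four aryl groups on this nitrogen are phenyl rings carrying an alkyl group or a chlorine, so it remains open whether a phenyl carrying an amine or a carboxylic acid would keep the read-out level with these compounds. Within the data shown here, no single-place step links the core of compound 1 to that of compound 2, so any contribution of the core itself to permeability also remains open.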